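The source may report more compounds than this note shows. Statements on the series, on what has been measured and on what is new or still open speak of the compounds shown alone.

In a functional assay on aorta (Rattus norvegicus, strain Wistar) for inhibition, with a stated time of 60 min (on this read-out lower numbers stand for an effect already at smaller amounts and higher numbers for an effect only at larger amounts of compound), compound 2 `FC(F)(F)c1ccc2[nH]c(-c3ccccc3)nc2c1` gives 468000 nM, and compound 1 `CCCOc1ccc(-c2nc3cc(C(F)(F)F)ccc3[nH]2)cc1` gives 524000 nM; the two numbers lie within the scatter of each other, as the step of a 1.1-fold lower number from compound 1 to compound 2 (0.05 log units; within the scatter) shows. Compound 3 `O=[N+]([O-])c1ccccc1-c1nc2cc(C(F)(F)F)ccc2[nH]1` differs from compound 2 by nitro in place of hydrogen on an aromatic carbon. Among the compounds with values here, the one measured step concerned a different position and stayed within the scatter, so it offers no guide beyond suggesting that small changes on this core leave this assay largely unmoved. Compound 3 is therefore expected to give about 450000 nM, between 150000 nM and 1400000 nM, a change of a 1.0-fold lower number from compound 2 to compound 3 (0.02 log units; within the scatter) that is not expected to exceed the scatter.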

Compound 3, half-maximal effective concentration: 15000 nM
The estimate for compound 3 lay 30-fold (1.48 log units) above the measured number, outside the stated range (below it).
By their numbers in this assay, from the lowest: compound 3; then compounds 2 and 1 (each within the scatter of the next).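

In this assay, nitro in place of hydrogen on an aromatic carbon, ortho to a large group, gives a 31-fold lower number from compound 2 to compound 3 (1.49 log units; beyond the scatter), a large step beyond the scatter. The earlier pair, which concerned a different position, gave no sign that a single change on the shared core could move this read-out so far. No measurement at hand bears on what lies behind this step.

As far as these compounds go, it remains open whether the step belongs to nitro itself or to substitution at this place more generally. An amine, a carboxylic acid or a methoxy group at this carbon would help to separate the two.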